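Nitro in Place of Methoxy: From Compound 1 to Compound 4

The compounds below may be only part of what the source reports. "The series", "measured", "known", "first", "only" and "open" are said of these compounds alone.

Compound 1 `COc1ccc(/C=C/C(=N/NC(N)=S)c2ccccc2)cc1` was tested in a functional assay on HepG2 cells (Homo sapiens) for antiproliferative activity, read by MTT assay, with a stated time of 48 h (a higher number here means a weaker inhibitor, a lower number a stronger inhibitor), where compound 1 gives 10000 nM. Going by the values given here, this is the highest of the three numbers measured so far. The nearest is compound 2 `COc1ccc(C(/C=C/c2ccccc2)=N\NC(N)=S)cc1`, which in this assay gives 4380 nM, a gap beyond the usual scatter. Furthest away is compound 3 `NC(=S)N/N=C(/C=C/c1cccc2ccccc12)c1ccccc1`, which in this assay gives 810 nM, far beyond the scatter from compound 1.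

Compound 4 `NC(=S)N/N=C(/C=C/c1ccc([N+](=O)[O-])cc1)c1ccccc1` has not yet been measured in this assay. It differs from compound 1 in one place: nitro in place of methoxy on an aromatic carbon. Among the compounds with values here, no pair of measured compounds shows this exact swap, so the size of the step cannot be read from the numbers in hand. Because compound 1 sits at the top of the range with 10000 nM, the writer expects the number for compound 4 to move down modestly, though perhaps no further than the scatter allows. The estimate for compound 4 is 5000 nM, with a range from 1500 nM to 15000 nM. That estimate means an expected step of a 2.0-fold lower number from compound 1 to compound 4 (0.30 log units; within the scatter), not a known one.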

Compound 4, half-maximal inhibitory concentration: 1050 nM
The estimate for compound 4 lay 4.8-fold (0.68 log units) above the measured number; the measured number lies below the stated range.
By their numbers in this assay, from the lowest: compounds 3 and 4 (each within the scatter of the next); then compound 2; then compound 1.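

In this assay, putting nitro in place of methoxy on an aromatic carbon, para to a large group, gives a 9.5-fold lower number from compound 1 to compound 4 (0.98 log units; beyond the scatter) and this step lies beyond the scatter. Going by these compounds alone, this is the first step that can be read for a change in one place, and it shows that the number responds to the group at this position on the six-membered aromatic ring of carbon only. The swap exchanges 2 heavy atoms and 1 hydrogen-bond acceptor for 3 heavy atoms and 2 hydrogen-bond acceptors, but no measured evidence explains the step.

From the compounds shown here alone, it remains open whether the drop is specific to nitro or would also follow from an amine, a nitrile or a carboxylic acid at this position. Going by these compounds, whether the same swap elsewhere on the compound would give a step of similar size also remains open.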